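From thiophen-3-yl to ethynyl on a shared core

The source may report more compounds than this note shows. Statements on the series, on what has been measured and on what is new or still open speak of the compounds shown alone.

Measured in a functional assay on A549 cells (Homo sapiens), read by MTT assay, with a stated time of 72 h; a higher number here means a weaker inhibitor, a lower number a stronger inhibitor:
Compound 1 `CSc1ncnc2c1c(-c1cccs1)cn2[C@@H]1O[C@H](CO)[C@@H](O)[C@H]1O`: > 20000 nM, a limit
Compound 2 `CSc1ncnc2c1c(-c1ccsc1)cn2[C@@H]1O[C@H](CO)[C@@H](O)[C@H]1O`: > 20000 nM, a limit

Compound 2 has no exact number in this assay, since its result of > 20000 nM is a limit of the assay. Neither measured compound gives more than this: the limit of > 20000 nM in this assay, at which 2 of the 2 values shown sit. Among the measured compounds shown here, the only measured step, a step that the two limits leave unreadable from compound 1 to compound 2, therefore has no readable size, and it exchanges one thiophene attachment for another.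

Compound 3 `C#Cc1cn([C@@H]2O[C@H](CO)[C@@H](O)[C@H]2O)c2ncnc(SC)c12` keeps the shared core but carries a different kind of group: ethynyl in place of thiophen-3-yl on an aromatic carbon. For the measured compounds named here, no measured step covers a change of this kind, so the data offer no size to carry over. Going by the values given here, the only anchor is compound 2 at > 20000 nM, which is again a limit. Compound 3 could well stay at that limit, and any readable number would mean a stronger inhibitor. The expected step is an at least 1.3-fold lower number from compound 2 to compound 3 (0.12 log units; that floor lies within the scatter), and this estimate is very uncertain. For compound 3 the estimated value is 15000 nM, with an expected range from 1000 nM to 30000 nM.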

Compound 3, half-maximal inhibitory concentration: 140 nM
Estimate against measurement, compound 3: 110-fold (2.03 log units) above, outside the stated range (below it).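

Ethynyl at this position gives an at least 140-fold lower number from compound 2 to compound 3 (2.15 log units; beyond the scatter), and in place of the other thiophene attachment it gives an at least 140-fold lower number from compound 1 to compound 3 (2.15 log units; beyond the scatter), both measured in this assay. Among the compounds shown here, the step between the two thiophene compounds cannot be read, so they could not show whether the group on this aromatic carbon matters at all, whereas compound 3, at 140 nM, gives the first exact number on the shared core and shows that it does. Both new steps are floors rather than exact sizes, because their starting points are limits and not numbers: the limit of > 20000 nM in this assay, at which 2 of the 3 values shown sit.

On these data alone, what remains open is which part of the change counts, since the swap removes the five-membered aromatic ring, reduces the group from 5 heavy atoms to 2 and brings in a triple bond all at once. The compounds shown also do not tell how a methyl, a nitrile, an amine or a longer chain ending in a triple bond would behave on this same carbon.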